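A few compounds are considered here, and "the series" means these few. Any claim that something is new, unique, unknown or untested is made for them only; others in the source may bear on it.

In an ADME assay on L02 cells (Homo sapiens) for inhibition, read by CCK-8 assay, with a stated time of 48 h (a lower number here means a stronger inhibitor of growth, a higher number a weaker inhibitor of growth), compound 2 `Cc1ccccc1Nc1nc(Nc2ccc(N3CCN(C)CC3)cn2)ncc1Cl` gives 5980 nM. Its number is the smallest of the three measured, yet it sits within the scatter of both neighbours: compound 1 `Cc1ccccc1Nc1nc(Nc2ccccn2)ncc1Cl` gives 6150 nM and compound 3 `Cc1ccccc1Nc1nc(Nc2ccc(N3CCN(C)CC3)cc2)ncc1Cl` gives 6510 nM in this assay. For the measured compounds named here, the one single-point step among them, a 1.0-fold lower number from compound 1 to compound 2 (0.01 log units; within the scatter), adds a 4-methylpiperazin-1-yl group in place of hydrogen on an aromatic carbon and changes nothing beyond the scatter.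

Compound 4 `CN1CCN(c2ccc(Nc3ncc(Cl)c(Nc4ccc(C(C)(C)C)cc4)n3)nc2)CC1` differs from compound 2 at the other end of the shared core: 4-(tert-butyl)phenyl in place of 2-methylphenyl on a nitrogen on an aromatic ring. Going by the values given here, no measured step touches this position, so nothing here speaks for a shift in either direction, and the three measured compounds all lie within the scatter of one another. Compound 4 is therefore expected to stay close to compound 2, with an estimated step of a 1.0-fold higher number from compound 2 to compound 4 (0.00 log units; within the scatter) in this assay. The estimate for compound 4 in this assay is 6000 nM, with a range from 2500 nM to 14000 nM.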

Compound 4, concentration for 50% growth inhibition: 6070 nM
Compound 4: the middle estimate sits 1.0-fold (0.01 log units) below what was measured; the range from low to high includes it.
By their numbers in this assay, from the lowest: compounds 2, 4, 1 and 3 (each within the scatter of the next).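

The earlier compounds shown here left this end of the shared core unchanged, whereas here, in this assay, 4-(tert-butyl)phenyl in place of 2-methylphenyl on a nitrogen on an aromatic ring gives a 1.0-fold higher number from compound 2 to compound 4 (0.01 log units; within the scatter). The position thus takes a group of 10 heavy atoms in place of one of 7, with a different placement of its substituent on the ring, and the number stays within the scatter, as it did for a 1.0-fold lower number from compound 1 to compound 2 (0.01 log units; within the scatter). Nothing measured offers an explanation for this lack of response.

On these data alone, whether a carboxylic acid or an amine in place of the tert-butyl group would carry the number beyond the scatter remains open. As far as these compounds go, the chlorine on the shared core is common to all four compounds, so the effect of a nitrile there also remains unknown.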